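The source may hold more compounds than are shown below. What is called first, only, known or untested is meant among the compounds shown, and "the series" means these compounds.

Measured so far:
compound 1 `COc1cc(OC)c(OC)cc1/C=C/C(=O)c1c(O)cc(C)oc1=O` — 100000 nM
compound 2 `COc1ccc(/C=C/C(=O)c2c(O)cc(C)oc2=O)cc1` — 100000 nM

In an ADME assay on HEK293 cells (Homo sapiens) for cytotoxicity, read by MTT assay (on this read-out lower numbers stand for stronger inhibition and higher numbers for weaker inhibition), compound 1 gives 100000 nM and compound 2 gives 100000 nM. The two values are level at the digits shown and lie within the usual scatter, so no order between compound 1 and compound 2 can be drawn from them. Compound 2 is the nearest reference point for compound 3 `Cc1ccc(/C=C/C(=O)c2c(O)cc(C)oc2=O)cc1`, which has not yet been measured. The structural change from compound 2 is methyl in place of methoxy on an aromatic carbon. For the measured compounds named here, no step between measured compounds for such a change is available, and the two values on hand do not differ. On this basis no step beyond the scatter is expected in this assay; the expected step is no change at the digits printed from compound 2 to compound 3 (within the scatter), essentially flat. Compound 3 is estimated at 100000 nM, with a range from 50000 nM to 100000 nM.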

Compound 3, half-maximal inhibitory concentration: > 100000 nM
Compound 3: a limit, no number; the forecaster's own chance of this, stated with the estimate: 40%; the middle value sits exactly at the limit.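

In this assay compound 3 gives > 100000 nM, which is a limit of the assay and not a number. The step for methyl in place of methoxy on this aromatic carbon, para to a large group, is a number no lower from compound 2 to compound 3 (the limit leaves the size open) and its size cannot be read. What is new is the direction: this is the first single change at this place, and it brings no lower reading than compound 2, so the exchange does not move the series into the measurable range of this assay, and the result rests on a single value at the ceiling: the limit of > 100000 nM in this assay, at which 1 of the 3 values shown sits.

On these data alone, whether an amine or a carboxylic acid on this aromatic carbon would give a lower value stays open. Also open, as far as these compounds go, is how far compound 3 lies beyond the limit.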